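A few compounds are considered here, and "the series" means these few. Any claim that something is new, unique, unknown or untested is made for them only; others in the source may bear on it.

Of the compounds shown here, two have been measured in an assay on COS-7 cells for inhibition of patatin-like phospholipase domain-containing protein 2 (Mus musculus), tested at 200 uM (on this read-out lower numbers stand for less inhibition and higher numbers for more inhibition at the one concentration tested (going by the name of the read-out)), so far. Compound 1 `CCOC(=O)c1cccc(-c2ccc3c(c2)CCN3)c1` gives 66%, and compound 2 `CN(C)c1ccc(-c2cccc(N)c2)cc1` gives 70%. Compound 2 is the point of departure here; its result and that of compound 1 differ by less than the usual scatter of the measurement, so the two stand on equal footing.

Compound 3 `CC(C)OC(=O)Nc1cccc(-c2ccc(N(C)C)cc2)c1` is not yet measured. It differs from compound 2 in one place: isopropoxycarbonyl in place of hydrogen on a nitrogen on an aromatic ring. Within the data shown here, no pair of measured compounds shows this kind of change, so there is no measured step to lean on, and the expectation rests only on the single result of compound 2. The step from compound 2 to compound 3 in this assay is expected to be small, a number 10 percentage points lower from compound 2 to compound 3 (within the scatter), and it may well lie within the scatter. Compound 3 is therefore expected to give about 60%, most likely between 35% and 85%.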

Compound 3, a percentage reported as inhibition, at one concentration (the size of the read-out at that concentration, not a potency): 69%
For compound 3 the middle estimate is 9 percentage points below the measured one, within the range that was stated.
By their numbers in this assay, from the lowest: compounds 1, 3 and 2 (each within the scatter of the next).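

Putting isopropoxycarbonyl on the nitrogen on the aromatic ring gives a step in this assay of a number 1 percentage points lower from compound 2 to compound 3 (within the scatter), so compound 2 and compound 3 cannot be told apart on this read-out. Among these compounds, this is the first sign that this nitrogen can carry a sizeable group in place of its hydrogen without a readable loss of inhibition at the one concentration tested, which the two earlier compounds, differing in more than one place, could not show. Nothing available explains why the two results match.

On these data alone, it remains open whether the same nitrogen would accept other groups, such as an acetyl group, a benzyl group or a chain ending in a carboxylic acid. Because the read-out comes from one concentration and is not a potency, it also leaves open whether compound 2 and compound 3 would still match at lower concentrations.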